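This account rests on a few compounds, and the source may have more. Where it says the series, first, only, none or still open, it means among the compounds named here.

Series notes. In a functional assay on NCI-H460 cells (Homo sapiens) for inhibition, read by sulforhodamine B assay, with a stated time of 48 h (on this read-out lower numbers stand for higher toxicity in this test and higher numbers for lower toxicity in this test), compound 3 `COc1cc(-c2nn(-c3cccc(NC(=O)c4cccc(C(F)(F)F)c4)c3)cc2-c2ccncc2)ccc1Cl` reaches only a limit, > 50000 nM. Compound 1 `O=C(Nc1cccc(-n2cc(-c3ccncc3)c(-c3ccc(Cl)c(O)c3)n2)c1)Nc1cccc(C(F)(F)F)c1` likewise reaches only a limit, > 32500 nM. Compound 2 `COc1cc(-c2nn(-c3cccc(NC(=O)Nc4cc(C(F)(F)F)cc(C(F)(F)F)c4)c3)cc2-c2ccncc2)ccc1Cl` gives 16300 nM. Compound 3 therefore sits at the limit end of the three values shown, two of which are limits (the limit of > 32500 nM in this assay, at which 1 of the 3 values shown sits; (the limit of > 50000 nM in this assay, at which 1 of the 3 values shown sits)). Compound 4 `COc1cc(-c2nn(-c3cccc(NC(=O)Nc4ccc(Cl)c(Cl)c4)c3)cc2-c2ccncc2)ccc1Cl` differs from compound 3 by (3,4-dichlorophenyl)amino in place of 3-(trifluoromethyl)phenyl on a carbonyl carbon. For the measured compounds named here, no measured pair covers this change. Going by the values given here, compound 2, the only compound with a number, 16300 nM, carries the same amino group on its carbonyl carbon as compound 4. The step from compound 3 to compound 4 is therefore expected to move toward lower numbers, an at least 2.5-fold lower number from compound 3 to compound 4 (0.39 log units; beyond the scatter), its size uncertain given the limit. Compound 4 is estimated at 20000 nM (range 7000 nM to 60000 nM).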

Compound 4, concentration lethal to 50% of the cells: > 50000 nM
Compound 4 gave a limit, no number; the forecaster's own chance of this, stated with the estimate: 35%; middle value at least 2.5-fold (0.39 log units) from the limit.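

In this assay, compound 3 and compound 4 both give only limits, so the step between them cannot be read. Going by these compounds, whether (3,4-dichlorophenyl)amino in place of 3-(trifluoromethyl)phenyl on a carbonyl carbon shifts the read-out remains open.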